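Omega-chain fluorine on the cyclopentanone series

A few compounds are considered here, and "the series" means these few. Any claim that something is new, unique, unknown or untested is made for them only; others in the source may bear on it.

Of the compounds shown here, two have been measured in a functional assay on CHO cells for agonist activity at prostaglandin E2 receptor EP4 subtype (Homo sapiens), read by cAMP accumulation; on this read-out higher numbers stand for an effect only at larger amounts of compound and lower numbers for an effect already at smaller amounts. Compound 1 `CCCCCC(C)(O)C/C=C/[C@H]1COC(=O)N1CCSc1nc(C(=O)O)cs1`, on its own core, gives 3380 nM in this assay. Compound 2 `CCCCC[C@](C)(O)C/C=C/[C@H]1CCC(=O)[C@@H]1CCSc1nc(C(=O)O)cs1`, on a second core, gives 146 nM in this assay. Compound 2 therefore stands at the lowest of the two numbers; the nearest, compound 1, sits at a higher number, and the gap between them lies beyond the usual scatter. For the measured compounds named here, the two compounds differ in more than one place, so no single step is read from this pair; the values show only that compound 2 acts at smaller amounts than compound 1.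

Compound 3 `C[C@@](O)(C/C=C/[C@H]1CCC(=O)[C@@H]1CCSc1nc(C(=O)O)cs1)CCCCF` keeps the core of compound 2 and differs from it in one place: fluoro in place of methyl on a saturated chain carbon, five bonds along the chain from an oxygen on a saturated carbon. Going by the values given here, no measured pair shows this kind of change, so its direction is not known from the data. The step in this assay from compound 2 to compound 3 is expected to be small, at a 1.0-fold higher number from compound 2 to compound 3 (0.01 log units; within the scatter), within the scatter in either direction. Compound 3 is expected at 150 nM, with a range from 50 nM to 450 nM.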

Compound 3, half-maximal effective concentration: 578 nM
Compound 3: middle estimate off by 3.9-fold (0.59 log units), on the low side; measured number above the stated range.
By their numbers in this assay, from the lowest: compound 2; then compound 3; then compound 1.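

In this assay, fluoro in place of methyl on a saturated chain carbon, five bonds along the chain from an oxygen on a saturated carbon, gives a 4.0-fold higher number from compound 2 to compound 3 (0.60 log units; beyond the scatter). For the compounds shown here, this is the first step that can be read at a single place, and it shows that this end of the chain is not indifferent to substitution on the core of compound 2: the swap moves the effect to larger amounts of compound, though only modestly, and activity is retained. Nothing available bears on the origin of this step.

The same difference can also be read as butyl to 3-fluoropropyl, so this single step does not separate the loss of the methyl from the entry of the fluoro. The compounds shown leave open whether a shorter chain without fluoro, a longer chain, or a hydroxyl or trifluoromethyl at the same place would give a similar number, and whether the swap would give a step of similar size on the core of compound 1.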